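The source may hold more compounds than are shown below. What is called first, only, known or untested is meant among the compounds shown, and "the series" means these compounds.

Measured so far:
Compound 1, `C=CC[N+](C)(C)c1cccc(OC)c1`, > 3000 nM
Compound 2, `C=CC[N+](C)(C)c1cccc(OC(C)=O)c1`, 3870 nM
Compound 3, `COc1cccc([N+](C)(C)Cc2ccccc2)c1`, > 3000 nM

All three were tested in a functional assay with Cavia porcellus as the target; on this read-out higher numbers stand for weaker inhibition and lower numbers for stronger inhibition. For compound 1 the reading is only a limit of the assay, not a number: > 3000 nM. Compound 2 gives a number, 3870 nM. For compound 3 the reading is again a limit of the assay and not a number: > 3000 nM. Compound 1 and compound 2 are related by one change, (acetyl in place of methyl on an oxygen on an aromatic ring), and this gives the step that the limit leaves unreadable from compound 1 to compound 2. Compound 1 and compound 3 differ in their cores by phenyl in place of vinyl on a saturated chain carbon bound to a nitrogen on an aromatic ring, which gives the step that the two limits leave unreadable from compound 1 to compound 3. Both steps cannot be sized because of the limit of > 3000 nM in this assay, at which 2 of the 3 values shown sit.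

Compound 4, `CC(=O)Oc1cccc([N+](C)(C)Cc2ccccc2)c1`, has not yet been measured. Among the measured compounds shown here, it differs from compound 3 by acetyl in place of methyl on an oxygen on an aromatic ring, which is the same change as the one from compound 1 to compound 2, and the place is the same word for word. The earlier step of this kind could not be read, so the expected size of the step to compound 4 is also uncertain; from compound 3 the expected step is a step that the limit leaves unreadable from compound 3 to compound 4, resting on compound 2 giving 3870 nM. Compound 4 is therefore estimated at 5000 nM in this assay, between 2500 nM and 15000 nM, with a fair chance that only a limit is reported.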

Compound 4, half-maximal inhibitory concentration: > 3000 nM
Compound 4: no number, only a limit; the forecaster's own chance of this, stated with the estimate: 50%; the middle value lies beyond the limit too.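

Compound 4 gives only a limit of the assay and not a number, so neither the step to it from compound 3 nor the step to it from compound 2 can be read, because most readings stop at the same point: the limit of > 3000 nM in this assay, at which 3 of the 4 values shown sit.

The compounds shown leave open how much acetyl in place of methyl on the oxygen, or phenyl in place of vinyl on the chain, changes inhibition in this assay.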